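Methoxy to nitro: working notes on a small series

The compounds below may be only part of what the source reports. "The series", "measured", "known", "first", "only" and "open" are said of these compounds alone.

Measured in a functional assay on A549/CDDP cells (Homo sapiens) for antiproliferative activity, read by MTT assay, with a stated time of 72 h; a higher number here means a weaker inhibitor, a lower number a stronger inhibitor:
compound 1 `COc1cc(/C=C/C(=O)/C=C/c2nc(C)c(C)nc2C)ccc1O` gives 600 nM
compound 2 `COc1ccccc1/C=C/C(=O)/C=C/c1nc(C)c(C)nc1C` gives 4740 nM
compound 3 `COc1ccc(/C=C/C(=O)/C=C/c2nc(C)c(C)nc2C)c(OC)c1` gives 2850 nM

Compound 2 stands at the weak end of these numbers, together with compound 3: the measured 1.7-fold lower number from compound 2 to compound 3 (0.22 log units; within the scatter) does not separate them. Compound 1, at 600 nM, lies well under compound 2, at 4740 nM.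

The next structure is compound 4 `Cc1nc(C)c(/C=C/C(=O)/C=C/c2ccccc2[N+](=O)[O-])nc1C`, with nitro in place of methoxy on an aromatic carbon.

Among the compounds with values here, no measured step makes this exchange. The nearest evidence is a 1.7-fold lower number from compound 2 to compound 3 (0.22 log units; within the scatter), where methoxy comes in place of hydrogen on an aromatic carbon, and that step is small. It gives only indirect support and shows no direction for nitro. A step beyond the scatter in this assay is therefore not expected, though the uncertainty is wide.

The expected change is a 1.2-fold lower number from compound 2 to compound 4 (0.07 log units; within the scatter). In this assay the estimate for compound 4 is 4000 nM, with an expected range of 1600 nM to 10000 nM.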

Compound 4, half-maximal inhibitory concentration: 6390 nM
Beside the measured number, compound 4's estimate is 1.6-fold (0.20 log units) below it; the range from low to high includes it.
By their numbers in this assay, from the lowest: compound 1; then compounds 3, 2 and 4 (each within the scatter of the next, the first and the last beyond it).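

On an aromatic carbon ortho to a large group, the exchange of methoxy for nitro now has a direct reading in this assay: a 1.3-fold higher number from compound 2 to compound 4 (0.13 log units; within the scatter). Until this point, compounds 2 and 3 had shown only methoxy at this place, so the series held no reading for any other group there; this step shows that a group with more heavy atoms and more hydrogen-bond acceptors can stand there without a change beyond the scatter. No supporting measurement offers an explanation for this result.

From the compounds shown here alone, it remains open whether this tolerance extends to other groups at this place, such as an amine or a carboxylic acid. Also open, going by these compounds, is whether the exchange of methoxy for nitro would read the same on another aromatic carbon of this ring.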